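Amide nitrogen substituents: expectation for compound 4

The source may hold more compounds than are shown below. What is called first, only, known or untested is meant among the compounds shown, and "the series" means these compounds.

Compound 1 `COc1ccc2c(=O)c(/C=C/C(=O)Nc3cccc(C)c3)coc2c1`: in a functional assay on HeLa cells (Homo sapiens) for inhibition, read by MTT assay, with a stated time of 48 h (on this read-out lower numbers stand for stronger inhibition and higher numbers for weaker inhibition), compound 1 gives > 100000 nM, a limit of the assay and not a number.
Compound 2 `COc1ccc2c(=O)c(/C=C/C(=O)Nc3ccccc3Cl)coc2c1`: in this assay compound 2 gives 22400 nM.
Compound 3 `COc1ccc(CNC(=O)/C=C/c2coc3cc(OC)ccc3c2=O)cc1`: in this assay compound 3 gives > 100000 nM, again a limit of the assay.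

Compound 3 therefore sits at the limit, one of the two values there (the limit of > 100000 nM in this assay, at which 2 of the 3 values shown sit), and its ordering against compound 1 is not readable: a step that the two limits leave unreadable from compound 1 to compound 3. Against compound 2 the step is readable: an at least 4.4-fold higher number from compound 2 to compound 3 (0.64 log units; beyond the scatter). The change to compound 4 `COc1ccc2c(=O)c(/C=C/C(=O)Nc3ccccc3C)coc2c1` is 2-methylphenyl in place of 4-methoxybenzyl on an amide-type nitrogen. It undoes the kind of change made on the way from compound 2 to compound 3, bringing back a substituted phenyl group on the amide nitrogen, here a 2-methylphenyl instead of the 2-chlorophenyl of compound 2. The step from compound 1 to compound 2, an at least 4.4-fold lower number from compound 1 to compound 2 (0.64 log units; beyond the scatter), shows that substituted phenyl groups are not interchangeable, so a return to the level of compound 2 is uncertain. The expected step is an at least 2.5-fold lower number from compound 3 to compound 4 (0.39 log units; beyond the scatter), a lower number, with a real chance that compound 4 remains at the limit. Compound 4 is estimated at 40000 nM, within the range 15000 nM to 100000 nM.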

Compound 4, half-maximal inhibitory concentration: 7270 nM
Compound 4: the middle estimate sits 5.5-fold (0.74 log units) above what was measured; measured number below the stated range.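

In this assay, 2-methylphenyl on the amide nitrogen gives the strongest inhibition of the four compounds, with an at least 13-fold lower number from compound 3 to compound 4 (1.13 log units; beyond the scatter) and an at least 13-fold lower number from compound 1 to compound 4 (1.13 log units; beyond the scatter), so a substituted phenyl group here can do much better than 4-methoxybenzyl or 3-methylphenyl. Going by these compounds alone, compound 1 and compound 3 each stand at a limit and not at a number: the limit of > 100000 nM in this assay, at which 2 of the 4 values shown sit. Methyl in place of chloro on the aromatic carbon also matters, with a 3.1-fold lower number from compound 2 to compound 4 (0.49 log units; beyond the scatter), the only step in this set between two true numbers.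

Going by these compounds, whether a 2-ethylphenyl or 2-aminophenyl group on the amide nitrogen would give a lower number than compound 4 remains open. On these data alone, the full size of the steps starting from compound 1 and compound 3 also remains unknown.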